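The source may report more compounds than this note shows. Statements on the series, on what has been measured and on what is new or still open speak of the compounds shown alone.

Compound 1 `S=C(Nc1ccccc1)N1N=C(c2ccc(Cl)cc2)CC1c1ccc2c(c1)OCCO2` gives 195000 nM in a functional assay on A-375 cells (Homo sapiens) for antiproliferative activity, read by MTT assay, with a stated time of 48 h; a higher number here means a weaker inhibitor of growth, a lower number a stronger inhibitor of growth.
Compound 2 `S=C(Nc1ccccc1)N1N=C(c2ccc(Br)cc2)CC1c1ccc2c(c1)OCCO2` gives 470 nM in this assay.

Of the two numbers in this assay, compound 2 stands lowest at 470 nM, while compound 1 sits far higher, giving 195000 nM. Compound 3 `S=C(Nc1ccccc1)N1N=C(c2ccc(Cl)c(Cl)c2)CC1c1ccc2c(c1)OCCO2` differs from compound 2 by 3,4-dichlorophenyl in place of 4-bromophenyl on a carbon with a double bond to nitrogen. Within the data shown here, only one measured step touches this part of the structure: a 410-fold lower number from compound 1 to compound 2 (2.62 log units; beyond the scatter), showing that the halogen on that ring can move the number a great deal. Since compound 3 returns to chloro while adding a second chloro, an upward step is expected, a 13-fold higher number from compound 2 to compound 3 (1.11 log units; beyond the scatter), with wide uncertainty. Compound 3 is estimated at 6000 nM, in a range from 400 nM to 100000 nM.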

Compound 3, concentration for 50% growth inhibition: 41900 nM
For compound 3 the middle estimate is 7.0-fold (0.84 log units) below the measured one; low and high end bracket the measured number.
By their numbers in this assay, from the lowest: compound 2; then compound 3; then compound 1.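

In this assay, the 3,4-dichlorophenyl group does not match the 4-bromophenyl group on this carbon, with an 89-fold higher number from compound 2 to compound 3 (1.95 log units; beyond the scatter). Adding a second chloro to the chlorinated ring recovers only a modest part of the gap between the chloro and bromo compounds, with a 4.7-fold lower number from compound 1 to compound 3 (0.67 log units; beyond the scatter). No measurement at hand explains these differences. Still open, on these data alone, is whether a 4-iodophenyl, 4-methoxyphenyl or 3,4-dibromophenyl group on this carbon would give a number nearer that of compound 2 or that of compound 1.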